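Piperazine nitrogen substituent in the aminothiophene ketone series

The compounds below may be only part of what the source reports. "The series", "measured", "known", "first", "only" and "open" are said of these compounds alone.

Compound 1 `CC(C)N1CCN(Cc2csc(N)c2C(=O)c2ccc(Cl)cc2)CC1` carries an isopropyl on the piperazine nitrogen. In a functional assay on CHO cells with adenosine receptor A1 (Homo sapiens) as the target, read by cAMP accumulation and immunoassay, with a stated time of 6 min, tested at 10 uM (on this read-out higher numbers stand for a weaker effect at the one concentration tested and lower numbers for a stronger effect), compound 1 gives -7.4%, the highest of the two numbers recorded so far. Compound 2 `Nc1scc(CN2CCN(c3cccc(C(F)(F)F)c3)CC2)c1C(=O)c1ccc(Cl)cc1` gives -80% in this assay. For the measured compounds named here, the one measured step, a number 72.6 percentage points lower from compound 1 to compound 2 (beyond the scatter), exchanges the isopropyl for an aryl group on the same nitrogen and is the only guide available.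

Compound 3 `Nc1scc(CN2CCN(c3ccccc3C(F)(F)F)CC2)c1C(=O)c1ccc(Cl)cc1` differs from compound 1 by 2-(trifluoromethyl)phenyl in place of isopropyl on an amine nitrogen in a ring. The change resembles the step to compound 2 in kind, with the trifluoromethyl moved on the phenyl, and the step from compound 1 to compound 2 was large and downward. As far as these compounds go, a large downward step in this assay is therefore expected for compound 3 as well, though the isomer is untested and the size is uncertain. The estimate for compound 3 is -55%, with a range from -85% to -5%, meaning an expected step of a number 47.6 percentage points lower from compound 1 to compound 3 (beyond the scatter).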

Compound 3, a percentage reported as activity, at one concentration (the size of the read-out at that concentration, not a potency): -60%
Compound 3: the middle estimate sits 5 percentage points above what was measured, within the range that was stated.
By their numbers in this assay, from the lowest: compound 2; then compound 3; then compound 1.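

The step of a number 52.6 percentage points lower from compound 1 to compound 3 (beyond the scatter) in this assay shows that the large downward change on this ring nitrogen is not tied to a single placement of the trifluoromethyl on the phenyl. The placement still matters, however: the step of a number 20 percentage points higher from compound 2 to compound 3 (beyond the scatter) shows that 2-(trifluoromethyl)phenyl and 3-(trifluoromethyl)phenyl are not interchangeable here, with the former giving the weaker effect of the two. No measurement shown explains this difference between the isomers.

The compounds shown do not separate the contribution of the phenyl ring from that of the trifluoromethyl, which a plain phenyl or a methoxyphenyl on the same nitrogen could address. Also open, as far as these compounds go, is how these differences at a single concentration relate to potency, and whether a benzyl group on this nitrogen would behave like the directly attached aryl groups.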